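The compounds below may be only part of what the source reports. "The series", "measured", "known", "first", "only" and "open" are said of these compounds alone.

Compound 2 `COc1ccc(-n2nc(C(=O)Nc3ccc(C)cc3)nc2-c2cc(OC)c(OC)c(OC)c2)cc1` is the starting point of this step. In a functional assay on the whole organism for inhibition, with Rattus norvegicus as the target, read by paw edema, with stated times of 30 min and 1 h, at a dose of 0.28 mmol/kg by the oral route (on this read-out lower numbers stand for less inhibition and higher numbers for more inhibition at the one dose given (going by the name of the read-out)), compound 2 gives 38%, and compound 1 `COc1ccc(NC(=O)c2nc(-c3cc(OC)c(OC)c(OC)c3)n(-c3ccc(OC)cc3)n2)cc1` gives 39%; the two cannot be told apart, because a number 1 percentage points lower from compound 1 to compound 2 (within the scatter). Compound 3 `COc1ccc(-n2nc(C(=O)Nc3ccccc3C)nc2-c2cc(OC)c(OC)c(OC)c2)cc1` differs from compound 2 by 2-methylphenyl in place of 4-methylphenyl on an amide-type nitrogen. For the measured compounds named here, no measured step moves a group to another place on a ring; the only step known exchanges methyl for methoxy and does not bear on this change. Compound 3 is therefore expected to show a step of no change at the digits printed from compound 2 to compound 3 (within the scatter), nothing beyond the scatter. The estimate for compound 3 is 38%, with a range from 25% to 50%.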

Compound 3, a percentage reported as inhibition, in the whole organism at one dose (the size of the read-out at that dose, not a potency): 19%
Compound 3: the middle estimate sits 19 percentage points above what was measured, outside the stated range (below it).
By their numbers in this assay, from the lowest: compound 3; then compounds 2 and 1 (each within the scatter of the next).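

In this assay, where the methyl sits on the ring attached to the amide-type nitrogen makes a real difference: with the same atoms, 2-methylphenyl in place of 4-methylphenyl gives a number 19 percentage points lower from compound 2 to compound 3 (beyond the scatter) and so goes beyond the scatter. Set against the 4-methoxyphenyl group, the same 2-methylphenyl group gives a number 20 percentage points lower from compound 1 to compound 3 (beyond the scatter) in the same direction, whereas exchanging methyl for methoxy on the ring had shown no clear change. Nothing measured here explains this drop. On these data alone, it remains open whether the drop is tied to methyl itself, as 2-methoxyphenyl or 2-chlorophenyl could show. An amine or a carboxylic acid on this ring also remains untested among the compounds shown.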